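Swapping Bromo for Methoxy: What to Expect for Compound 4

A few compounds are considered here, and "the series" means these few. Any claim that something is new, unique, unknown or untested is made for them only; others in the source may bear on it.

Measured so far in a functional assay on A549 cells (Homo sapiens) for antiproliferative activity, read by MTT assay, with a stated time of 48 h; a lower number here means a stronger inhibitor, a higher number a weaker inhibitor:
compound 1, `COc1ccc(-c2nnc(-c3cn4ccccc4n3)o2)cc1`, gives 11900 nM;
compound 3, `Cc1cccn2cc(-c3nnc(-c4ccc(Br)cc4)o3)nc12`, gives 34700 nM.
Compound 2, `Brc1ccc(-c2nnc(-c3cn4ccccc4n3)o2)cc1`, reaches only a limit of the assay, > 50000 nM.

The change methoxy in place of bromo on an aromatic carbon turns compound 2 into compound 1 and brings an at least 4.2-fold lower number from compound 2 to compound 1 (0.62 log units; beyond the scatter); that step is a floor, since compound 2 sits at the limit of > 50000 nM in this assay, at which 1 of the 3 values shown sits. Compound 4, `COc1ccc(-c2nnc(-c3cn4cccc(C)c4n3)o2)cc1`, is not yet measured and carries the same change, (methoxy in place of bromo on an aromatic carbon), on the core of compound 3; the two places read alike word for word. The two cores differ by methyl in place of hydrogen on an aromatic carbon, a step of an at least 1.4-fold lower number from compound 2 to compound 3 (0.15 log units; that floor lies within the scatter). Compound 4 is expected to show a 5.0-fold lower number from compound 3 to compound 4 (0.70 log units; beyond the scatter) because the same change gave an at least 4.2-fold lower number from compound 2 to compound 1 (0.62 log units; beyond the scatter). The estimate for compound 4 in this assay is 7000 nM, likely between 2000 nM and 20000 nM.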

Compound 4, half-maximal inhibitory concentration: 12800 nM
Compound 4: the middle estimate sits 1.8-fold (0.26 log units) below what was measured, and the stated range covers the measured number.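

In this assay, methoxy in place of bromo gives a 2.7-fold lower number from compound 3 to compound 4 (0.43 log units; beyond the scatter), so the direction of this change is the same on both cores shown. Compound 2 gives only a limit, so the new step shows nothing about whether the size of the change carries over: the same change on two cores in this assay, an at least 4.2-fold lower number (0.62 log units; beyond the scatter) from compound 2 to compound 1 and a 2.7-fold lower number (0.43 log units; beyond the scatter) from compound 3 to compound 4; the limit leaves it open whether they differ. Methyl in place of hydrogen gives a 1.1-fold higher number from compound 1 to compound 4 (0.03 log units; within the scatter), which shows no difference beyond the scatter with methoxy present, and a comparison with the bromo pair stays equally open: the same change on two cores in this assay, an at least 1.4-fold lower number (0.15 log units; that floor lies within the scatter) from compound 2 to compound 3 and a 1.1-fold higher number (0.03 log units; within the scatter) from compound 1 to compound 4; the limit leaves it open whether they differ.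

The compounds shown leave open how an amine, a carboxylic acid or a longer chain such as ethoxy would behave in place of methoxy. They also leave open whether the direction of the change would hold on any further core.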